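The source may report more compounds than this note shows. Statements on the series, on what has been measured and on what is new or still open speak of the compounds shown alone.

Working notes on the series.

The shared core carries two arylidene arms. Compound 1 `COc1ccccc1/C=c1/[nH]c(=O)/c(=C\c2cccc(Cl)c2Cl)[nH]c1=O`, compound 2 `C=CCn1c(=O)/c(=C\c2cccc(F)c2)[nH]c(=O)/c1=C\c1ccccc1OC` and compound 3 `C=CCn1c(=O)/c(=C\c2ccc(Cl)c(Cl)c2)[nH]c(=O)/c1=C\c1ccccc1OC` have been run in a functional assay on A549 cells (Homo sapiens) for cytotoxicity, read by CCK-8 assay, with a stated time of 72 h; on this read-out lower numbers stand for stronger inhibition and higher numbers for weaker inhibition. Compound 2 gives 19700 nM in this assay. Compound 1 is reported in this assay as "not active" (no number reported), with no number attached. Compound 3 likewise is reported in this assay as "not active" (no number reported), so no single number places it; it shares this standing with one further compound of the set, and against compound 2 it can only be said that compound 2 has a number where compound 3 has none.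

Compound 4 `C=CCn1c(=O)/c(=C\c2ccccc2C(F)(F)F)[nH]c(=O)/c1=C\c1ccccc1OC` has not yet been measured. It differs from compound 3 in one place: 2-(trifluoromethyl)phenyl in place of 3,4-dichlorophenyl on a double-bonded chain carbon bound to an aromatic carbon. Within the data shown here, no measured pair in the set matches this change, so its size and direction cannot be read from the data. Given that compound 3 returns no number and that compound 2, the only compound with a number, gives 19700 nM, compound 4 is expected to be weak in this assay and may again return no number. On balance compound 4 is estimated at 30000 nM in this assay, with a range of 8000 nM to 120000 nM.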

Compound 4, half-maximal inhibitory concentration: 7000 nM
Compound 4: the middle estimate sits 4.3-fold (0.63 log units) above what was measured; the measured number lies below the stated range.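

Within the compounds that carry a number, this assay gives a first readable step at this place on a double-bonded chain carbon bound to an aromatic carbon: 2-(trifluoromethyl)phenyl in place of 3-fluorophenyl gives a 2.8-fold lower number from compound 2 to compound 4 (0.45 log units; beyond the scatter). The change from 3,4-dichlorophenyl to 2-(trifluoromethyl)phenyl also shows that the choice of aryl group at this place separates a compound reported without a number, compound 3, from one with a number, compound 4. No measured data on the series bear on why these differences arise.

The compounds shown do not separate the contribution of the trifluoromethyl group from that of its ring placement. On these data alone, it also stays open how this arm would respond to a phenyl carrying an amine or a carboxylic acid.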